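Compound 3: longer chain in place of the small selenium group

The source may hold more compounds than are shown below. What is called first, only, known or untested is meant among the compounds shown, and "the series" means these compounds.

Measured in a functional assay on RKO cells (Homo sapiens) for inhibition, read by MTT assay, with a stated time of 48 h; on this read-out higher numbers stand for weaker inhibition and lower numbers for stronger inhibition:
- compound 1 `Cc1nc(N(C)c2ccc([Se]C#N)c(C)c2)c2ccccc2n1`: 17 nM
- compound 2 `COc1ccc(N(C)c2nc(C)nc3ccccc23)cc1[Se]C`: 11 nM

In this assay, compound 2 gives 11 nM, and this value lies within the usual scatter of the value for compound 1. For the measured compounds named here, the two values therefore set no order between these compounds. Both sit in the same low range, and that range is the only reference available for the next compound.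

Compound 3 `COc1ccc(N(C)c2nc(C)nc3ccccc23)cc1OCCCCC[Se]C#N` has not yet been measured. It is related to compound 2 by the change (a group of 9 heavy atoms (6 carbon, 1 nitrogen, 1 oxygen, 1 selenium; no ring) in place of a group of 2 heavy atoms (1 carbon, 1 selenium; no ring), on an aromatic carbon). The change falls on an aromatic carbon, ortho to a methoxy group, and the rest of the structure stays the same.

Going by the values given here, no measured step covers a change of this kind, so the data give no direct guide to its size. A moderate to large rise in the number, beyond the scatter, is expected, meaning weaker inhibition than the 11 nM of compound 2. The expected change is a 14-fold higher number from compound 2 to compound 3 (1.13 log units; beyond the scatter).

For compound 3 the estimated value is 150 nM, with an expected range from 30 nM to 800 nM.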

Compound 3, half-maximal inhibitory concentration: 3560 nM
Compound 3: the middle estimate sits 24-fold (1.38 log units) below what was measured, outside the stated range (above it).
By their numbers in this assay, from the lowest: compounds 2 and 1 (each within the scatter of the next); then compound 3.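

In this assay, for the compounds shown here, the aromatic carbon ortho to a methoxy group proves sensitive to what it carries: a group of 9 heavy atoms (6 carbon, 1 nitrogen, 1 oxygen, 1 selenium; no ring) in place of a group of 2 heavy atoms (1 carbon, 1 selenium; no ring) gives a 320-fold higher number from compound 2 to compound 3 (2.51 log units; beyond the scatter), the only step that can be read. This position therefore does not treat all selenium-bearing groups alike: the small group of compound 2 goes with a low number and the long chain of compound 3 with a much higher one, although selenium and the shared core are present in both. No measurement at hand accounts for this loss of inhibition.

The change alters the chain length, the oxygen on the ring and the nitrile on selenium all at once, so the compounds shown do not separate these parts. A shorter chain ending in the same selenium nitrile, or a chain of the same length ending in an amine, would show whether the rise follows the length of the chain or its end group.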